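The source may hold more compounds than are shown below. What is called first, only, known or untested is meant among the compounds shown, and "the series" means these compounds.

Measured compounds:
- compound 1 `COc1ncc(-c2ccc3c(c2)N(c2ccc(C)cc2)C(=O)CO3)cc1NS(=O)(=O)c1ccc(F)cc1` gives 12900 nM in a functional assay on A-375 cells (Homo sapiens) for antiproliferative activity, read by MTT assay, with a stated time of 72 h; on this read-out lower numbers stand for stronger inhibition and higher numbers for weaker inhibition
- compound 2 `Cc1ccc(N2C(=O)COc3ccc(-c4cnc(Cl)c(NS(=O)(=O)c5ccc(F)cc5)c4)cc32)cc1` gives 38900 nM in this assay
- compound 3 `COc1ccc(N2C(=O)COc3ccc(-c4cccc(NS(=O)(=O)c5ccc(F)cc5)c4)cc32)cc1` gives 38500 nM in this assay

Compound 1 stands lowest of the three numbers in this assay, and both of the other compounds are separated from it by a step beyond the usual scatter. Compound 4 `COc1cccc(N2C(=O)COc3ccc(-c4cnc(OC)c(NS(=O)(=O)c5ccc(F)cc5)c4)cc32)c1` has not yet been measured. It differs from compound 1 in one place: 3-methoxyphenyl in place of 4-methylphenyl on an amide-type nitrogen in a ring.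

Within the data shown here, only one single-point step has been measured, a 3.0-fold higher number from compound 1 to compound 2 (0.48 log units; beyond the scatter), and that step changes the other aromatic ring, not the group on the amide-type nitrogen, so it says nothing direct about the change leading to compound 4. Among the measured compounds shown here, compound 3 carries a methoxyphenyl on that nitrogen, but it also differs from compound 1 elsewhere, so its value and that of compound 1 show only that the two-place change gives a higher number. For the measured compounds named here, with no measured step bearing on the change itself, compound 4 is expected to stay close to compound 1, with a step no larger than the scatter, a 1.2-fold higher number from compound 1 to compound 4 (0.07 log units; within the scatter). Compound 4 is therefore estimated at 15000 nM, within a range from 5000 nM to 45000 nM.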

Compound 4, half-maximal inhibitory concentration: > 40000 nM
Compound 4 gave a limit, no number; the forecaster's own chance of this, stated with the estimate: 10%; middle value at least 2.6-fold (0.42 log units) from the limit.
By their numbers in this assay, from the lowest: compound 1; then compounds 3 and 2 (each within the scatter of the next). At a limit, above all of these: compound 4.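

Among these compounds, this position was the one place so far without a direct measurement, and the group on the amide-type nitrogen in the ring now proves not to be a free choice. With the rest of the core of compound 1 kept unchanged, placing 3-methoxyphenyl there instead of 4-methylphenyl gives, in this assay, an at least 3.1-fold higher number from compound 1 to compound 4 (0.49 log units; beyond the scatter). This is the first single-place comparison at this nitrogen, whereas compound 3 differs from compound 1 in more than one place and could not isolate the change, and for compound 4 the result is a limit, not a number: the limit of > 40000 nM in this assay, at which 1 of the 4 values shown sits.

The compounds shown leave open whether this step goes with the methoxy group itself or with where a group sits on the phenyl ring, and a 3-methylphenyl or 4-methoxyphenyl on the same nitrogen, with the core of compound 1 unchanged, would help to tell these apart. Going by these compounds, how a plain phenyl, or a phenyl carrying an amine or a carboxylic acid, would compare with compound 1 at this nitrogen also remains open.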